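This account rests on a few compounds, and the source may have more. Where it says the series, first, only, none or still open, it means among the compounds named here.

Of the compounds shown here, two have so far been measured in a functional assay on Jurkat cells (Homo sapiens) for activation, with a stated time of 24 h; on this read-out higher numbers stand for an effect only at larger amounts of compound and lower numbers for an effect already at smaller amounts. Compound 1 `Oc1ccccc1CNc1ccc(-c2ccc(F)cc2)cc1` gives 3860 nM. Compound 2 `Oc1ccccc1CNc1ccc(-c2ccc(Cl)cc2)cc1` gives 2390 nM. For the measured compounds named here, compound 2 thus stands at the lower of the two numbers, but its only neighbour, compound 1, lies within the scatter of it, so the two cannot be told apart on these data. Going by the values given here, the single measured step, a 1.6-fold lower number from compound 1 to compound 2 (0.21 log units; within the scatter), is too small to count as a real change.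

Compound 3 `Cc1ccccc1-c1ccc(NCc2ccccc2O)cc1` has not yet been measured. It differs from compound 2 in one place: 2-methylphenyl in place of 4-chlorophenyl on an aromatic carbon. Among the compounds with values here, the only measured step that bears on this change is the one from compound 1 to compound 2, which also exchanged one group on an aromatic carbon and stayed within the scatter, so it offers no ground for expecting a large move in either direction. The step is therefore expected to be a 1.3-fold higher number from compound 2 to compound 3 (0.10 log units; within the scatter), within the scatter. Compound 3 is estimated at 3000 nM, with a range from 1200 nM to 8000 nM.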

Compound 3, half-maximal effective concentration: 5220 nM
The estimate for compound 3 lay 1.7-fold (0.24 log units) below the measured number; low and high end bracket the measured number.
By their numbers in this assay, from the lowest: compounds 2, 1 and 3 (each within the scatter of the next, the first and the last beyond it).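

In this assay, for the compounds shown here, the exchange of 4-chlorophenyl for 2-methylphenyl, on an aromatic carbon para to a group of 9 heavy atoms, gives a 2.2-fold higher number from compound 2 to compound 3 (0.34 log units; beyond the scatter) and so produces the first step at this position to pass beyond the scatter, though only modestly. The same position does not respond that clearly when the group leaving is 4-fluorophenyl: the exchange gives a 1.4-fold higher number from compound 1 to compound 3 (0.13 log units; within the scatter) and leaves those two compounds indistinguishable, so the readable difference holds only against compound 2, and the counts of heavy atoms, rings, hydrogen-bond donors and acceptors do not separate 4-chlorophenyl from 2-methylphenyl. Nothing available here accounts for this difference.

The compounds shown leave open whether the step from compound 2 follows from losing the chlorine or from where the methyl group sits, a question that 4-methylphenyl and 2-chlorophenyl would address directly. They also leave open how this position would respond to a group of a different kind, such as an amine or a carboxylic acid on the outer ring.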